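Aryl Sulfonyl Replacing a Carbonyl Group on the Ring Nitrogen

A few compounds are considered here, and "the series" means these few. Any claim that something is new, unique, unknown or untested is made for them only; others in the source may bear on it.

Compound 1 `CN1CCN(c2ccc(C3=NNC(c4ccc(N(C)C)cc4)C3)cc2)CC1` — 11.4%
Compound 2 `CN1CCN(c2ccc(C3=NN(S(=O)(=O)c4ccc(Br)cc4)C(c4ccc(N(C)C)cc4)C3)cc2)CC1` — 23.7%
Compound 3 `C=C(C)C(=O)N1N=C(c2ccc(-n3ccnc3)cc2)CC1c1ccc(N(C)C)cc1` — 4.3%

Of the compounds shown here, three have been measured in a functional assay on MDA-MB-231 cells (Homo sapiens) for inhibition, read by sulforhodamine B assay, tested at 10 uM; a higher number here means more inhibition at the concentration tested (going by the name of the read-out), a lower number less inhibition. Compound 3 sits at the low end of the three numbers; its gap to compound 1 is within the usual scatter, and only compound 2 lies beyond the scatter above it.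

Compound 4 `CN(C)c1ccc(C2CC(c3ccc(-n4ccnc4)cc3)=NN2S(=O)(=O)c2ccc([N+](=O)[O-])cc2)cc1` differs from compound 3 in one place: (4-nitrophenyl)sulfonyl in place of (1-methylethenyl)carbonyl on an amine nitrogen in a ring

Among the compounds with values here, one measured step bears on this change. The step of a number 12.3 percentage points higher from compound 1 to compound 2 (beyond the scatter) put a (4-bromophenyl)sulfonyl onto the same kind of ring nitrogen and raised the read-out modestly. The comparison is imperfect: there hydrogen left, whereas here (1-methylethenyl)carbonyl leaves, and the entering group carries a nitro rather than a bromo substituent. Within the data shown here, still, an aryl sulfonyl entering on that nitrogen is the common feature, so a modest rise of roughly the size seen from compound 1 to compound 2 is the most reasonable expectation for this assay, with a wide range because no step exactly matches.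

Compound 4 is therefore expected to give about 16% in this assay, between 0% and 35%, a step of a number 11.7 percentage points higher from compound 3 to compound 4 (beyond the scatter).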

Compound 4, a percentage reported as inhibition, at one concentration (the size of the read-out at that concentration, not a potency): 41.5%
The estimate for compound 4 lay 25.5 percentage points below the measured number; measured number above the stated range.
By their numbers in this assay, from the lowest: compounds 3 and 1 (each within the scatter of the next); then compound 2; then compound 4.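

Exchanging (1-methylethenyl)carbonyl for (4-nitrophenyl)sulfonyl on the amine nitrogen in the ring gave, in this assay, a number 37.2 percentage points higher from compound 3 to compound 4 (beyond the scatter) and so a large step. Within the data shown here, the only earlier step at this kind of nitrogen, a number 12.3 percentage points higher from compound 1 to compound 2 (beyond the scatter) with hydrogen leaving, was modest, so the new result shows that the read-out can move much further when an aryl sulfonyl replaces a carbonyl group there on the core of compound 3. No measurement shown here explains why this step is so large.

The compounds shown leave open whether the gain belongs to the sulfonyl link or to the nitro group, which a (4-bromophenyl)sulfonyl or a methylsulfonyl on the core of compound 3 would help to separate. On these data alone, it also remains open whether an amine or a carboxylic acid in place of the nitro group would keep the read-out, and whether the inhibition seen at one concentration reflects potency.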